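This account rests on a few compounds, and the source may have more. Where it says the series, first, only, none or still open, it means among the compounds named here.

Notes on the series.

Compound 1 `O=C(Nc1cccc(Cl)c1)c1ccccc1O` and compound 2 `COc1ccccc1C(=O)Nc1cccc(Cl)c1` share one core; compound 3 `O=C(Nc1ccc(Sc2nc3ccccc3s2)cc1)c1cc(Br)cc(Br)c1O` carries another, and the difference between the two cores is not broken down here. Compound 4 `COc1c(Br)cc(Br)cc1C(=O)Nc1ccc(Sc2nc3ccccc3s2)cc1` is the compound still to be measured.

In an assay for inhibition of HSP60/HSP10 (Homo sapiens), with a stated time of 60 min (on this read-out higher numbers stand for weaker inhibition and lower numbers for stronger inhibition), compound 1 gives > 100000 nM, which is a limit of the assay and not a number. Compound 2 gives > 100000 nM in this assay, again a limit rather than a number. The change between them is methyl in place of hydrogen on an oxygen on an aromatic ring, and it leaves a step that the two limits leave unreadable from compound 1 to compound 2, so its size cannot be read from this pair. Among the measured compounds shown here, compound 3, the only compound with a number, gives 4700 nM in this assay.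

Compound 4 carries the same change relative to compound 3 that compound 2 carries relative to compound 1: methyl in place of hydrogen on an oxygen on an aromatic ring, with the place described in the same words in both pairs. Since the measured pair gives no readable size for this change, the expectation for compound 4 rests on compound 3 alone, at 4700 nM, and on the hydroxy group being turned into methoxy. Given (the limit of > 100000 nM in this assay, at which 2 of the 3 values shown sit), where compound 1 and compound 2 both sit after this same kind of change has been made or not, the step from compound 3 to compound 4 is expected to be a 6.4-fold higher number from compound 3 to compound 4 (0.81 log units; beyond the scatter), toward weaker inhibition. Compound 4 is therefore estimated at 30000 nM in this assay, between 8000 nM and 150000 nM, with a fair chance that only a limit is returned.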

Compound 4, half-maximal inhibitory concentration: > 100000 nM
Compound 4 gave a limit, no number; the forecaster's own chance of this, stated with the estimate: 40%; middle value at least 3.3-fold (0.52 log units) from the limit.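

On the core of compound 3, methyl in place of hydrogen on the oxygen, that is hydroxy to methoxy, gives an at least 21-fold higher number from compound 3 to compound 4 (1.32 log units; beyond the scatter) in this assay, so on this core a single change is enough to lose the measurable value. Compound 4 gives > 100000 nM in this assay, which is a limit of the assay and not a number, so the step has a lower bound and no full size. The step on the core of compound 1 cannot be read, so the two steps cannot be compared and nothing here shows that the change has the same size on both cores; the only shared feature is that both methoxy compounds end at the limit, where most of the series sits: the limit of > 100000 nM in this assay, at which 3 of the 4 values shown sit.

Among the compounds shown here, still open is whether the hydroxy group is the only group tolerated at this place on the core of compound 3, for instance whether an amine in its place, or an ethyl group or longer chain on the oxygen, would return a number in this assay. The compounds shown also leave open which part of the core of compound 3 separates it from the core of compound 1, as those two cores differ in more than one place.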